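The source may report more compounds than this note shows. Statements on the series, on what has been measured and on what is new or still open speak of the compounds shown alone.

Measured compounds:
- Compound 1, `C[C@@H](NC(=O)Nc1ccc(C(F)(F)F)cc1)c1ccccc1`, in an ADME assay on the whole organism with Oryza sativa as the target, tested at 1 uM (a lower number here means a stronger effect, a higher number a weaker effect of the compound at the concentration tested), compound 1 gives 89%.
- Compound 2, `C[C@@H](NC(=O)Nc1cccc(F)c1)c1ccccc1`, in this assay compound 2 gives 95%.
- Compound 3, `C[C@@H](NC(=O)Nc1ccc(F)cc1)c1ccccc1`, in this assay compound 3 gives 96%.

Compound 3 has the highest of the three numbers in this assay, but its companions lie close: compound 2 is within the scatter of it, and compound 1 is also within the scatter. The one step among these compounds, a number 7 percentage points higher from compound 1 to compound 3 (within the scatter), changed trifluoromethyl to fluoro on an aromatic carbon and stayed within the scatter.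

Compound 4, `C[C@@H](NC(=O)Nc1ccc(F)c(F)c1)c1ccccc1`, has not yet been measured in this assay. It differs from compound 3 by fluoro in place of hydrogen on an aromatic carbon. Within the data shown here, no measured step adds a fluoro in place of hydrogen, so the only guidance is that every change seen so far, including a number 7 percentage points higher from compound 1 to compound 3 (within the scatter), left the number where it was. For compound 4 the step of a number 3 percentage points lower from compound 3 to compound 4 (within the scatter) is therefore expected to stay within the scatter. Compound 4 is estimated at 93%, in a range from 80% to 100%.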

Compound 4, a percentage reported as activity, at one concentration (the size of the read-out at that concentration, not a potency): 99%
The estimate for compound 4 lay 6 percentage points below the measured number, and the stated range covers the measured number.
By their numbers in this assay, from the lowest: compounds 1, 2, 3 and 4 (each within the scatter of the next).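

Among these compounds, the second fluoro, placed ortho to a fluoro group and meta to a large group, gave a number 3 percentage points higher from compound 3 to compound 4 (within the scatter) in this assay, so this is the first measured replacement of hydrogen on the aromatic ring, and it did not move the number beyond the scatter. Read from the other monofluoro compound, the same kind of change gave a number 4 percentage points higher from compound 2 to compound 4 (within the scatter), so both single-step routes to the difluoro compound stay within the scatter. Nothing available explains these small steps or links them to any property of the compounds.

Only fluoro has been shown entering at this position, so an amine or a carboxylic acid there could behave differently. Going by these compounds, whether either of these, or a longer chain in place of the methyl on the shared core, would move the number beyond the scatter remains open.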